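The compounds below may be only part of what the source reports. "The series", "measured", "known", "first", "only" and "open" are said of these compounds alone.

Compound 1 `CCOC(=O)c1oc2ccc(N(Cc3ccccc3)S(=O)(=O)c3ccc(C)cc3)cc2c1C` and compound 2 `CCOC(=O)c1oc2ccc(N(Cc3ccccc3)S(=O)(=O)c3ccc(OC)cc3)cc2c1C` share their core with compound 3 `CCOC(=O)c1oc2ccc(N(Cc3ccccc3)S(=O)(=O)c3ccc(Cl)cc3)cc2c1C`; the first two carry methyl or methoxy on the aromatic carbon where compound 3 carries chloro. In a functional assay on HCT-116 cells (Homo sapiens) for inhibition, read by MTT assay, with a stated time of 72 h (on this read-out lower numbers stand for stronger inhibition and higher numbers for weaker inhibition), compound 1 reaches only the limit > 40000 nM and gives no number. Compound 2 likewise gives only the limit > 40000 nM. Among the compounds with values here, compound 3 gives 4860 nM, the sole number among the three, and both steps of an at least 8.2-fold lower number from compound 1 to compound 3 (0.91 log units; beyond the scatter) and an at least 8.2-fold lower number from compound 2 to compound 3 (0.91 log units; beyond the scatter) run towards it, set against (the limit of > 40000 nM in this assay, at which 2 of the 3 values shown sit). Compound 4 `CCOC(=O)c1oc2ccc(N(Cc3ccccc3)S(=O)(=O)c3ccccc3)cc2c1C` differs from compound 3 by hydrogen in place of chloro on an aromatic carbon. Since both measured steps point to chloro as the stronger choice, its removal is expected to raise the number, a step of a 4.1-fold higher number from compound 3 to compound 4 (0.61 log units; beyond the scatter). Compound 4 is accordingly estimated at 20000 nM, within 6000 nM to 60000 nM.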

Compound 4, half-maximal inhibitory concentration: > 40000 nM
Compound 4 ended at the assay's limit; the forecaster's own chance of this, stated with the estimate: 45%; at least 2.0-fold (0.30 log units) between middle value and limit.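

Hydrogen in place of chloro gives an at least 8.2-fold higher number from compound 3 to compound 4 (0.91 log units; beyond the scatter) in this assay, so the number of compound 3 is now set against the unsubstituted phenyl as well, not only against methyl and methoxy. Among these compounds, only the 4-chlorophenyl group gives a number. The steps among compound 1, compound 2 and compound 4 cannot be read, and hydrogen, methyl and methoxy stay unordered: the limit of > 40000 nM in this assay, at which 3 of the 4 values shown sit.

From the compounds shown here alone, whether fluoro, bromo or a nitrile on this carbon would keep or lower the number stays open. A single number also leaves no order of groups to read.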